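The source may report more compounds than this note shows. Statements on the series, on what has been measured and on what is new or still open speak of the compounds shown alone.

In a functional assay on MGC-803 cells (Homo sapiens) for inhibition, read by MTT assay, with a stated time of 48 h (on this read-out higher numbers stand for weaker inhibition and lower numbers for stronger inhibition), compound 3 `Cc1ccc(S(=O)(=O)N(Cc2nc3ccccc3[nH]2)c2ccccc2)cc1` gives 45200 nM, the highest of the three numbers in hand. Compound 2 `Cc1ccc(S(=O)(=O)N(Cc2nc3ccccc3[nH]2)c2ccc(Cl)cc2)cc1` gives 24800 nM; the step of a 1.8-fold higher number from compound 2 to compound 3 (0.26 log units; within the scatter) lies within the scatter. Compound 1 `COc1ccc(CN(c2cc(OC)c(OC)c(OC)c2)S(=O)(=O)c2c(C)cc(C)cc2C)cc1` gives 6440 nM, beyond the scatter from compound 3, but differs from it in several places at once. Compound 4 `COc1ccc(N(Cc2nc3ccccc3[nH]2)S(=O)(=O)c2ccc(C)cc2)cc1OC` arises from compound 3 by 3,4-dimethoxyphenyl in place of phenyl on a sulfonamide nitrogen. Among the measured compounds shown here, no measured step alters the group on the sulfonamide nitrogen alone; the one measured step, from compound 2 to compound 3, concerns an aromatic carbon and lies within the scatter. Compound 1, which also carries methoxy groups on that nitrogen, gives 6440 nM, and on that alone a modest move toward lower numbers is expected, a 2.3-fold lower number from compound 3 to compound 4 (0.35 log units; beyond the scatter). Compound 4 is thus estimated at 20000 nM, in the range 6000 nM to 60000 nM in this assay.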

Compound 4, half-maximal inhibitory concentration: > 50000 nM
Compound 4 gave a limit, no number (the forecaster's own chance of this, stated with the estimate: 5%); middle value at least 2.5-fold (0.39 log units) from the limit.
By their numbers in this assay, from the lowest: compound 1; then compounds 2 and 3 (each within the scatter of the next). At a limit, above all of these: compound 4.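

In this assay, compound 4 is recorded as a limit, not a number: the limit of > 50000 nM in this assay, at which 1 of the 4 values shown sits.

Among the compounds shown here, this gives the only reading of a change on the sulfonamide nitrogen: 3,4-dimethoxyphenyl in place of phenyl gives an at least 1.1-fold higher number from compound 3 to compound 4 (0.04 log units; that floor lies within the scatter), and in place of 4-chlorophenyl gives an at least 2.0-fold higher number from compound 2 to compound 4 (0.30 log units; that floor lies within the scatter). Adding these two methoxy groups on this core therefore brings no move toward lower numbers, although neither floor fixes the size of its step.

Open, on these data alone, is whether a single methoxy group, a hydroxy group or an amine on that phenyl ring would give a lower number. As far as these compounds go, how far compound 4 lies past its limit also stays open.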